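Cytotoxicity of three oxadiazoles and a fourth, unmeasured analogue

The source may report more compounds than this note shows. Statements on the series, on what has been measured and on what is new or still open speak of the compounds shown alone.

Measured compounds:
compound 1, `Brc1ccccc1-c1nnc(-c2ccc(-n3cccc3)cc2)o1`, 258000 nM
compound 2, `Brc1ccc(-c2nnc(-c3ccc(-n4cccc4)cc3)o2)cc1`, 260000 nM
compound 3, `O=[N+]([O-])c1ccc(-c2nnc(-c3ccc(-n4cccc4)cc3)o2)cc1`, 258000 nM

In an ADME assay on Vero cells (Chlorocebus sabaeus) for cytotoxicity, read by MTT assay, with a stated time of 72 h (on this read-out lower numbers stand for stronger inhibition and higher numbers for weaker inhibition), compound 1 gives 258000 nM, and the values of compound 2 and compound 3 sit at the same level, so no order among the three is claimed. The two cores differ as 2-bromophenyl in place of 4-bromophenyl on an aromatic carbon, and the step of a 1.0-fold higher number from compound 1 to compound 2 (0.00 log units; within the scatter) is flat. From compound 2 to compound 3 the change is nitro in place of bromo on an aromatic carbon, and the step of a 1.0-fold lower number from compound 2 to compound 3 (0.00 log units; within the scatter) is likewise flat. Compound 4, `O=[N+]([O-])c1ccccc1-c1nnc(-c2ccc(-n3cccc3)cc2)o1`, is not yet measured; it differs from compound 1 as nitro in place of bromo on an aromatic carbon. This is the same kind of change, but its place differs: ortho to a large group here, para to a large group before. Because a 1.0-fold lower number from compound 2 to compound 3 (0.00 log units; within the scatter) shows no movement, the expected step is no change at the digits printed from compound 1 to compound 4 (within the scatter). Compound 4 is therefore estimated at 258000 nM, between 150000 nM and 400000 nM.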

Compound 4, half-maximal inhibitory concentration: 266000 nM
For compound 4 the middle estimate is 1.0-fold (0.01 log units) below the measured one; the range from low to high includes it.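

In this assay, nitro in place of bromo on the core of compound 1 leaves the number flat, with a 1.0-fold higher number from compound 1 to compound 4 (0.01 log units; within the scatter). Set beside the earlier step, the change carries from one core to the other with no difference that can be told apart: the same change on two cores in this assay, a 1.0-fold lower number (0.00 log units; within the scatter) from compound 2 to compound 3 and a 1.0-fold higher number (0.01 log units; within the scatter) from compound 1 to compound 4, 1.0-fold (0.02 log units) apart, within the scatter of two such steps This shows that the change is flat on these two cores, but it does not show that it would stay flat on any other core, and two flat steps cannot say what either group contributes.

The compounds shown leave open whether an amine or a carboxylic acid in place of the bromo or nitro would move the number in this assay. They also leave open whether any change to the shared core would do so.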